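The source may hold more compounds than are shown below. What is called first, only, known or untested is meant among the compounds shown, and "the series" means these compounds.

Working notes on a set of four bis-heteroaryl amidines. Compound 1 `N=C(N)c1ccc(-c2ccc(-c3ccc(F)cc3)o2)o1` and compound 2 `N=C(N)c1ccc(-c2ccc(-c3ccc(Cl)cc3)o2)o1` share one core; compound 3 `N=C(N)c1ccc(-c2ccc(-c3ccc(Cl)cc3)s2)s1` and compound 4 `N=C(N)c1ccc(-c2ccc(-c3ccc(F)cc3)s2)s1` share another, and how the two cores differ is not broken down here. In a functional assay on HCC 2998 cells (Homo sapiens) for inhibition, read by sulforhodamine B assay, with a stated time of 48 h (a higher number here means a weaker inhibitor of growth, a lower number a stronger inhibitor of growth), compound 1 gives 1370 nM and compound 2 gives 1960 nM; the change fluoro in place of chloro on an aromatic carbon brings the step of a 1.4-fold lower number from compound 2 to compound 1 (0.16 log units; within the scatter). In this assay compound 3 gives 1570 nM, close to both. Going by these compounds, compound 4 is still untested; it differs from compound 3 by fluoro in place of chloro on an aromatic carbon, the same change as that made from compound 2 to compound 1. A step of like size is expected here, a 1.4-fold lower number from compound 3 to compound 4 (0.14 log units; within the scatter), resting on a 1.4-fold lower number from compound 2 to compound 1 (0.16 log units; within the scatter). Compound 4 is accordingly estimated at 1150 nM in this assay, with a plausible range from 600 nM to 2300 nM.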

Compound 4, concentration for 50% growth inhibition: 1730 nM
For compound 4 the middle estimate is 1.5-fold (0.18 log units) below the measured one; the measured number falls inside the stated range.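

In this assay, chloro to fluoro on the second core gives a 1.1-fold higher number from compound 3 to compound 4 (0.04 log units; within the scatter). Set beside the same change on the first core, the two steps agree: the same change on two cores in this assay, a 1.4-fold lower number (0.16 log units; within the scatter) from compound 2 to compound 1 and a 1.1-fold higher number (0.04 log units; within the scatter) from compound 3 to compound 4, 1.6-fold (0.20 log units) apart, within the scatter of two such steps. Among these compounds, this shows that on these two cores the change leaves the number within the scatter, but it does not establish a direction or size that carries from one core to another, and two pairs support no rule beyond these compounds.

The compounds shown leave open whether a group other than the two halogens at this place, such as an amine, a carboxylic acid or a methoxy group, would give a step beyond the scatter. They also leave open how a nitrile in place of the amidine would read.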